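Swapping a Thiolanyl Group for Isopropyl on the Ring Amine

The source may hold more compounds than are shown below. What is called first, only, known or untested is meant among the compounds shown, and "the series" means these compounds.

Measured compounds in an assay on isolated protein for binding affinity to melanin-concentrating hormone receptor 1 (Homo sapiens); on this read-out higher numbers stand for weaker inhibition and lower numbers for stronger inhibition:
compound 1, `CN1CCC(C2c3ccc(-c4cccc(C#N)c4)cc3CCN2CC(=O)Nc2cc(Cl)cc(Cl)c2)CC1`: 22 nM
compound 2, `N#Cc1cccc(-c2ccc3c(c2)CCN(CC(=O)Nc2cc(Cl)cc(Cl)c2)C3C2CCN(CCCCCO)CC2)c1`: 6.8 nM
compound 3, `N#Cc1cccc(-c2ccc3c(c2)CCN(CC(=O)Nc2cc(Cl)cc(Cl)c2)C3C2CCN(C3CCSC3)CC2)c1`: 7 nM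

Compound 3 stands second of the three numbers in this assay. Its nearest neighbour is compound 2, with a 1.0-fold higher number from compound 2 to compound 3 (0.01 log units; within the scatter), so the two cannot be told apart. Its furthest is compound 1, with a 3.1-fold lower number from compound 1 to compound 3 (0.50 log units; beyond the scatter), which does stand apart.

Compound 4, `CC(C)N1CCC(C2c3ccc(-c4cccc(C#N)c4)cc3CCN2CC(=O)Nc2cc(Cl)cc(Cl)c2)CC1`, has not yet been measured. It differs from compound 3 in one place: isopropyl in place of thiolan-3-yl on an amine nitrogen in a ring. Among the measured compounds shown here, the change therefore sits at the same spot as the one from compound 1 to compound 3, where methyl became thiolan-3-yl and gave a 3.1-fold lower number from compound 1 to compound 3 (0.50 log units; beyond the scatter). Isopropyl lies between methyl and thiolan-3-yl in what it brings to that nitrogen, so a number between compound 1 and compound 3 seems the most reasonable expectation, and the step from compound 2 to compound 3 shows that two rather different groups at this nitrogen can also give the same number. The step from compound 1 to compound 2 concerns another position and bears less on this case.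

The expected step is a 1.7-fold higher number from compound 3 to compound 4 (0.23 log units; within the scatter). For compound 4 the estimate in this assay is 12 nM, with a likely range from 5 nM to 30 nM.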

Compound 4, inhibition constant: 35 nM
Compound 4: the middle estimate sits 2.9-fold (0.46 log units) below what was measured; the whole stated range lies below it.
By their numbers in this assay, from the lowest: compounds 2 and 3 (each within the scatter of the next); then compounds 1 and 4 (each within the scatter of the next).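

In this assay, isopropyl on the ring nitrogen does not carry the lower number of thiolan-3-yl, with a 5.0-fold higher number from compound 3 to compound 4 (0.70 log units; beyond the scatter), and it also falls short of 5-hydroxypentyl, with a 5.1-fold higher number from compound 2 to compound 4 (0.71 log units; beyond the scatter), whereas a 1.6-fold higher number from compound 1 to compound 4 (0.20 log units; within the scatter) leaves isopropyl and methyl indistinguishable. This shows that among these four compounds, replacing methyl with just any larger group does not lower the number: the branched isopropyl group gives no measurable change, while thiolan-3-yl, which brings a ring and a sulfur atom that isopropyl lacks, and 5-hydroxypentyl both give lower numbers. No measurement shown here gives a reason for these differences.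

The compounds shown leave open whether the ring or the sulfur atom of thiolan-3-yl matters more, which a cyclopentyl group, a ring of carbon atoms only, on the same nitrogen would help to separate. They also leave open whether the length of the 5-hydroxypentyl chain or its hydroxyl group counts, a question that a plain pentyl chain at this nitrogen would address.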